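Thiosemicarbazone series: growth inhibition, step to compound 4

A few compounds are considered here, and "the series" means these few. Any claim that something is new, unique, unknown or untested is made for them only; others in the source may bear on it.

Measured so far:
compound 1 `CC1=CC[C@H](C(C)(C)N=C=S)CC1` — in a functional assay on OVCAR-3 cells (Homo sapiens) for inhibition, read by sulforhodamine B assay, with a stated time of 48 h (on this read-out higher numbers stand for weaker inhibition of growth and lower numbers for stronger inhibition of growth), compound 1 gives > 100000 nM, a limit of the assay and not a number.
compound 2 `CC1=CC[C@H](C(C)(C)NC(=S)N/N=C/c2ccc(O)cc2)CC1` — in this assay compound 2 gives > 100000 nM, again a limit of the assay and not a number.
compound 3 `CC1=CC[C@H](C(C)(C)NC(=S)N/N=C/c2ccc(N(C)C)cc2)CC1` — in this assay compound 3 gives > 100000 nM, also a limit of the assay and not a number.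

Compound 2 therefore stands only at a limit on the numbers shown, as do the two others. For the measured compounds named here, the one step among measured compounds, a step that the two limits leave unreadable from compound 2 to compound 3, is unreadable, since (the limit of > 100000 nM in this assay, at which 3 of the 3 values shown sit).

Compound 4 `CC1=CC[C@H](C(C)(C)NC(=S)N/N=C/c2cccc(Cl)c2)CC1` differs from compound 2 by 3-chlorophenyl in place of 4-hydroxyphenyl on a carbon with a double bond to nitrogen. Going by the values given here, no measured step reads on this change: the only neighbouring step is the unreadable one from compound 2 to compound 3, and the hydroxy-to-dimethylamino exchange there is not the same exchange. With every value in the series sitting at the limit, the expected outcome for compound 4 is once more a limit rather than a number. The step from compound 2 to compound 4 is accordingly expected as a step that the limit leaves unreadable from compound 2 to compound 4, no change beyond the scatter. Compound 4 is estimated at 150000 nM, within 40000 nM to 600000 nM.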

Compound 4, concentration for 50% growth inhibition: 13600 nM
The estimate for compound 4 lay 11-fold (1.04 log units) above the measured number; measured number outside the range, below it.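

In this assay, for the compounds shown here, compound 4 gives 13600 nM, the one number so far rather than a limit. The exchange of 4-hydroxyphenyl for 3-chlorophenyl on the carbon with a double bond to nitrogen gives an at least 7.3-fold lower number from compound 2 to compound 4 (0.86 log units; beyond the scatter), so the aromatic group at this place can bring growth inhibition into the measurable range. The other step in the series still cannot be read: the limit of > 100000 nM in this assay, at which 3 of the 4 values shown sit.

This change alters both the substituent and its place on the ring, so the compounds shown do not separate the gain of chlorine, the loss of hydroxy and the shift in position. Open too, going by these compounds, is how 4-chlorophenyl, 3-hydroxyphenyl or a phenyl ring carrying a nitrile or a carboxylic acid would read at this place.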